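Swapping an Amino for a Methoxy on the Ketone Ring

The source may hold more compounds than are shown below. What is called first, only, known or untested is meant among the compounds shown, and "the series" means these compounds.

Measured compounds:
- compound 1, `COc1cc(-c2cc(/C=C/C(=O)c3ccc(N)cc3)[nH]n2)cc(OC)c1OC`: 1420 nM
- compound 2, `COc1ccc(-c2cc(/C=C/C(=O)c3ccc(N)cc3)[nH]n2)cc1OC`: 4250 nM

Both compounds were tested in a functional assay on T47D cells (Homo sapiens) for inhibition, read by sulforhodamine B assay, with a stated time of 48 h; a lower number here means a stronger inhibitor of growth, a higher number a weaker inhibitor of growth. Within the data shown here, compound 1 gives 1420 nM, the lowest of the two numbers, and compound 2 sits at a step of a 3.0-fold higher number from compound 1 to compound 2 (0.48 log units; beyond the scatter), the only measured step here, where a methoxy group on one aromatic ring is replaced by hydrogen.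

Compound 3, `COc1ccc(C(=O)/C=C/c2cc(-c3cc(OC)c(OC)c(OC)c3)n[nH]2)cc1`, has not yet been measured. It differs from compound 1 in a single spot: methoxy in place of amino on an aromatic carbon. Among the measured compounds shown here, this change sits on the other aromatic ring, the one carrying the ketone, and no measured pair shows an exchange of this kind. The step from compound 1 to compound 2 concerns a different ring and a different group, so it gives at most a sense of scale, not a direction.

With nothing measured to anchor this swap, compound 3 is expected to land near compound 1, at a step of a 1.4-fold higher number from compound 1 to compound 3 (0.15 log units; within the scatter), with a wide range: the estimate is 2000 nM, between 700 nM and 6000 nM.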

Compound 3, concentration for 50% growth inhibition: 2310 nM
For compound 3 the middle estimate is 1.2-fold (0.06 log units) below the measured one; low and high end bracket the measured number.
By their numbers in this assay, from the lowest: compounds 1, 3 and 2 (each within the scatter of the next, the first and the last beyond it).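

In this assay, the exchange of 4-aminophenyl for 4-methoxyphenyl gives a 1.6-fold higher number from compound 1 to compound 3 (0.21 log units; within the scatter), so the two compounds cannot be told apart by their numbers. Among these compounds, this is the first measured change at this spot on the ring bearing the ketone, and it shows that the amino group, with its one hydrogen-bond donor, can give way to a methoxy group with no donor and one more heavy atom without a step beyond the scatter. No measurement given here explains this result, so the reason for it remains unknown.

This single pair says nothing about other groups at the same spot: a hydroxyl group, a fluorine atom or a carboxylic acid could give numbers close to those of compound 1 or far from them. It also leaves open whether the same exchange would stay within the scatter on the core of compound 2, which carries one methoxy group fewer than compound 1 on its other aromatic ring.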